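Cyclohexyl Amide Variant in a Thiourea Series

The compounds below may be only part of what the source reports. "The series", "measured", "known", "first", "only" and "open" are said of these compounds alone.

Compound 3 `O=C(NC1CC1)c1cc(Oc2cccc(NC(=S)Nc3cccc(C(F)(F)F)c3)c2)ccn1` gives 22100 nM in a functional assay on PC-3 cells (Homo sapiens) for cytotoxicity, read by MTT assay, with a stated time of 48 h (on this read-out lower numbers stand for stronger inhibition and higher numbers for weaker inhibition), the highest of the three numbers recorded there. Compound 2 `CCNC(=O)c1cc(Oc2cccc(NC(=S)Nc3cccc(C(F)(F)F)c3)c2)ccn1` gives 18300 nM in this assay, a value within the scatter of that of compound 3, while compound 1 `O=C(NC1CCCCC1)c1cc(Oc2cccc(NC(=S)Nc3ccc(F)c(F)c3)c2)ccn1` gives 8100 nM, clearly lower. For the measured compounds named here, the single step between two measured compounds that differ in one place, a 1.2-fold higher number from compound 2 to compound 3 (0.08 log units; within the scatter), shows that exchanging ethyl for cyclopropyl on the amide-type nitrogen left the number essentially unchanged. Compound 4 `O=C(NC1CCCCC1)c1cc(Oc2cccc(NC(=S)Nc3cccc(C(F)(F)F)c3)c2)ccn1` carries the change (cyclohexyl in place of cyclopropyl on an amide-type nitrogen). Going by the values given here, no measured pair isolates this exact change: compound 1, the only measured compound bearing a cyclohexyl on its amide-type nitrogen, also differs from compound 3 in the thiourea aryl group, so the two values can only be set side by side. Among the compounds with values here, the one step that does bear on the amide substituent was within the scatter, which argues against a large move. The step is therefore expected to be modest at most, with a slight lean toward a lower number because compound 1 with its cyclohexyl gives 8100 nM: a 1.7-fold lower number from compound 3 to compound 4 (0.23 log units; within the scatter). The estimate for compound 4 is 13000 nM, ranging from 5000 nM to 32000 nM.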

Compound 4, half-maximal inhibitory concentration: 16800 nM
Compound 4: the middle estimate sits 1.3-fold (0.11 log units) below what was measured; the range from low to high includes it.
By their numbers in this assay, from the lowest: compound 1; then compounds 4, 2 and 3 (each within the scatter of the next).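

With the 3-(trifluoromethyl)phenyl group held constant, the amide-type nitrogen now carries ethyl, cyclopropyl or cyclohexyl, and in this assay both steps to cyclohexyl, a 1.3-fold lower number from compound 3 to compound 4 (0.12 log units; within the scatter) and a 1.1-fold lower number from compound 2 to compound 4 (0.04 log units; within the scatter), lie within the scatter, so even this larger ring gives no readable change at this position. For the compounds shown here, compound 4 also supplies a comparison that the earlier compounds lacked, one that holds the cyclohexyl constant and exchanges only 3,4-difluorophenyl for 3-(trifluoromethyl)phenyl: a 2.1-fold higher number from compound 1 to compound 4 (0.32 log units; beyond the scatter), a modest step, but beyond the scatter, so the lower number of compound 1 goes with its aryl group and not with its cyclohexyl. Nothing available explains either result.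

Going by these compounds, whether the insensitivity of the amide-type nitrogen extends to substituents of another kind, such as a chain ending in an amine or a carboxylic acid, remains open. Also open, on these data alone, is whether the step between the two aryl groups would be the same size with ethyl or cyclopropyl on the amide-type nitrogen in place of cyclohexyl.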